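Chloro for methoxy on the pendant aryl: a repeated change

The source may report more compounds than this note shows. Statements on the series, on what has been measured and on what is new or still open speak of the compounds shown alone.

Compound 1 `Nc1cccc(-c2cn3nc(Cc4ccc(Cl)cc4)sc3n2)c1` and compound 2 `COc1ccc(Cc2nn3cc(-c4cccc(N)c4)nc3s2)cc1` share a core and differ only at the pendant aryl. In a functional assay on HeLa cells (Homo sapiens) for inhibition, read by cell counting, with a stated time of 4 days (a higher number here means a weaker inhibitor, a lower number a stronger inhibitor), compound 1 gives 25000 nM, while compound 2 gives 191000 nM. The change between them is chloro in place of methoxy on an aromatic carbon, which brings a 7.6-fold lower number from compound 2 to compound 1 (0.88 log units; beyond the scatter).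

Compound 3 `C=C(Br)C(=O)Nc1cccc(-c2cn3nc(-c4ccc(OC)cc4)sc3n2)c1` carries an acrylamide on the aniline and gives 2300 nM in this assay; its difference from the core of compound 2 is not broken down here.

Compound 4 `C=C(Br)C(=O)Nc1cccc(-c2cn3nc(-c4ccc(Cl)cc4)sc3n2)c1` is not yet measured. It differs from compound 3 by chloro in place of methoxy on an aromatic carbon, at a place described in the same words as for compound 1 and compound 2, so this is taken as the same change. Because compound 2 to compound 1 showed a 7.6-fold lower number from compound 2 to compound 1 (0.88 log units; beyond the scatter), a step of a 4.6-fold lower number from compound 3 to compound 4 (0.66 log units; beyond the scatter) is expected for compound 4, read in this assay. Compound 4 is therefore estimated at 500 nM, between 150 nM and 1600 nM.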

Compound 4, half-maximal inhibitory concentration: 3000 nM
Estimate against measurement, compound 4: 6.0-fold (0.78 log units) below; measured number outside the range, above it.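

Carried to the core of compound 3, the change from 4-methoxyphenyl to 4-chlorophenyl gives a 1.3-fold higher number from compound 3 to compound 4 (0.12 log units; within the scatter) in this assay. The effect of this change therefore does not carry over unchanged between these two cores: the same change on two cores in this assay, a 7.6-fold lower number (0.88 log units; beyond the scatter) from compound 2 to compound 1 and a 1.3-fold higher number (0.12 log units; within the scatter) from compound 3 to compound 4, 10-fold (1.00 log units) apart, beyond the scatter of two such steps

This rests on a single pair per core, and the two cores differ from each other in more than one place, so it does not show which feature of the core decides the outcome, nor whether the same split would recur on other cores. The compounds shown leave open how the two cores would compare with other groups at this place on the aryl ring, such as fluoro, a nitrile or a carboxylic acid. Also open, going by these compounds, is how the change would read with a plain acrylamide in place of the bromoacrylamide.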